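Amide-linked coumarin series: amine substituent on the propoxy chain

This account rests on a few compounds, and the source may have more. Where it says the series, first, only, none or still open, it means among the compounds named here.

Among the compounds with values here, compound 2 `CC(C)=CCc1cc(C(=O)Nc2cc3ccc(OCCCN(C)C(C)C)c(C)c3oc2=O)ccc1O` and compound 1 `CC(=O)Oc1ccc(C(=O)Nc2cc3ccc(OCC4CCCNC4)c(C)c3oc2=O)cc1CC=C(C)C` are the two measured members. In a functional assay on SK-BR-3 cells (Homo sapiens) for antiproliferative activity (a lower number here means a stronger inhibitor, a higher number a weaker inhibitor), compound 2 gives 570 nM, and compound 1 gives 620 nM; the two numbers lie within the usual scatter of one another, so neither is set apart. Compound 3 `CC(C)=CCc1cc(C(=O)Nc2cc3ccc(OCCCNC(C)(C)c4ccccc4)c(C)c3oc2=O)ccc1O` carries (1-methyl-1-phenylethyl)amino in place of isopropyl(methyl)amino on a saturated chain carbon, three bonds along the chain from an oxygen on an aromatic ring. Within the data shown here, no measured pair isolates this change, so the step from compound 2 to compound 3 is expected to stay within the scatter, in either direction, at a 1.1-fold lower number from compound 2 to compound 3 (0.06 log units; within the scatter). For compound 3 the estimate in this assay is 500 nM, with a range from 200 nM to 1500 nM.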

Compound 3, half-maximal inhibitory concentration: 960 nM
For compound 3 the middle estimate is 1.9-fold (0.28 log units) below the measured one; measured number inside the range.
By their numbers in this assay, from the lowest: compounds 2, 1 and 3 (each within the scatter of the next).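

In this assay, the chain position, on a saturated chain carbon, three bonds along the chain from an oxygen on an aromatic ring, now has its first single-place step: (1-methyl-1-phenylethyl)amino in place of isopropyl(methyl)amino gives (a 1.7-fold higher number from compound 2 to compound 3 (0.23 log units; within the scatter)). The position therefore accepts the larger group, with its six-membered aromatic ring and hydrogen-bond donor, without a shift beyond the scatter. No available evidence bears on this result.

Still open, as far as these compounds go, is whether any amine at this position separates from the others. A primary amine, a carboxylic acid or a longer chain could test this.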